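Will compound 4 stay as mild as compound 3?

The source may hold more compounds than are shown below. What is called first, only, known or untested is meant among the compounds shown, and "the series" means these compounds.

In a functional assay on Huh-7 cells (Homo sapiens) for cytotoxicity, read by MTT assay, with a stated time of 3 days (on this read-out lower numbers stand for higher toxicity in this test and higher numbers for lower toxicity in this test), compound 3 `OC[C@H]1O[C@@H](n2cnc3c(CSCc4ccccc4)ncnc32)[C@H](O)[C@@H]1O` gives > 100000 nM, which is a limit and not a number. Compound 1 `OC[C@H]1O[C@@H](n2cnc3c(COc4ccccc4)ncnc32)[C@H](O)[C@@H]1O` gives > 100000 nM, also a limit. Only compound 2 `CN(Cc1ncnc2c1ncn2[C@@H]1O[C@H](CO)[C@@H](O)[C@H]1O)c1ccccc1` gives a true number, 21000 nM. Compound 4 `O=c1ccn(Cc2ncnc3c2ncn3[C@@H]2O[C@H](CO)[C@@H](O)[C@H]2O)cc1` swaps the group on a saturated chain carbon bound to an aromatic carbon: a group of 7 heavy atoms (5 carbon, 1 nitrogen, 1 oxygen; one six-membered aromatic ring with 1 hetero atom) in place of a group of 8 heavy atoms (7 carbon, 1 sulfur; one six-membered aromatic ring of carbon only), on a saturated chain carbon bound to an aromatic carbon. Similar swaps at that place gave an at least 4.7-fold lower number from compound 1 to compound 2 (0.67 log units; beyond the scatter) and an at least 4.7-fold higher number from compound 2 to compound 3 (0.67 log units; beyond the scatter), while a step that the two limits leave unreadable from compound 1 to compound 3 cannot be sized. Compound 4 carries a nitrogen in its new group, as compound 2 does, so a modest drop in this assay is expected, though it may stay unreadable. The expected change is an at least 1.4-fold lower number from compound 3 to compound 4 (0.15 log units; that floor lies within the scatter). Compound 4 is estimated at 70000 nM, within an expected range of 20000 nM to 150000 nM.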

Compound 4, half-maximal cytotoxic concentration: > 100000 nM
Compound 4: only a limit was reported; the forecaster's own chance of this, stated with the estimate: 55%; middle value at least 1.4-fold (0.15 log units) from the limit.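

In this assay, a nitrogen in the group on the saturated chain carbon is not enough to give a lower number, as the swap from methyl(phenyl)amino to the new six-membered ring shows: an at least 4.7-fold higher number from compound 2 to compound 4 (0.67 log units; beyond the scatter). Among the compounds shown, methyl(phenyl)amino alone stands apart, and compound 4 joins the phenoxy and benzylsulfanyl compounds. The steps among compound 1, compound 3 and compound 4 cannot be read, since each of these values is a limit: the limit of > 100000 nM in this assay, at which 3 of the 4 values shown sit.

Going by these compounds, how these three compounds rank against one another stays open. So does whether a plain dimethylamino group at this place would also give a lower number.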